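Replacing the Nitro Group on the Shared Core

The compounds below may be only part of what the source reports. "The series", "measured", "known", "first", "only" and "open" are said of these compounds alone.

Compound 1 `CCOC(=O)c1cccc(-c2ccc(O)cc2)c1` and compound 2 `CCOC(=O)c1cccc(-c2ccc(OC)cc2)c1` share their core with compound 3 `CCOC(=O)c1cccc(-c2ccc([N+](=O)[O-])cc2)c1`. In an assay on COS-7 cells for inhibition of patatin-like phospholipase domain-containing protein 2 (Mus musculus), tested at 200 uM (a lower number here means less inhibition, a higher number more inhibition at the concentration tested (going by the name of the read-out)), compound 1 gives 77%, compound 2 gives 77% and compound 3 gives 63%, so compound 3 stands lowest of the three. The steps of a number 14 percentage points lower from compound 1 to compound 3 (beyond the scatter) and a number 14 percentage points lower from compound 2 to compound 3 (beyond the scatter) both lower the number by the same modest amount, while no change at the digits printed from compound 1 to compound 2 (within the scatter) shows hydroxy and methoxy alike. Compound 4 `CCOC(=O)c1cccc(-c2ccc(CN3CCCC3)cc2)c1` carries (pyrrolidin-1-yl)methyl in place of nitro on an aromatic carbon. For the measured compounds named here, no measured step covers this group, so the two nitro steps are the only guide, and groups other than nitro gave the higher numbers. Compound 4 is therefore expected to move back upward, a number 7 percentage points higher from compound 3 to compound 4 (within the scatter). Compound 4 is estimated at 70%, within 52% to 86%.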

Compound 4, a percentage reported as inhibition, at one concentration (the size of the read-out at that concentration, not a potency): 33%
The estimate for compound 4 lay 37 percentage points above the measured number; measured number outside the range, below it.
By their numbers in this assay, from the lowest: compound 4; then compound 3; then compounds 1 and 2 (each within the scatter of the next).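

In this assay this position proves able to lower the number far more than nitro did: the change gives a number 30 percentage points lower from compound 3 to compound 4 (beyond the scatter) and the larger steps of a number 44 percentage points lower from compound 2 to compound 4 (beyond the scatter) and a number 44 percentage points lower from compound 1 to compound 4 (beyond the scatter) place (pyrrolidin-1-yl)methyl under hydroxy, methoxy and nitro alike. Replacing nitro therefore does not always raise the number on the shared core. Nothing measured here bears on why the number falls this far. From the compounds shown here alone, whether the fall follows the ring or its nitrogen stays open. A cyclopentylmethyl group, a primary amine or a carboxylic acid at this position could separate these possibilities.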